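This account rests on a few compounds, and the source may have more. Where it says the series, first, only, none or still open, it means among the compounds named here.

Values in an ADME assay on MT4 cells (Homo sapiens) for cytotoxicity, read by MTT assay, with a stated time of 5 days; on this read-out higher numbers stand for lower toxicity in this test and lower numbers for higher toxicity in this test:
- compound 1 `Cc1cccc(C)c1Oc1cc(Nc2ccc(C#N)cc2)[nH]c(=O)c1Br`: 63000 nM
- compound 2 `Cc1cc(C)cc(Oc2cc(Nc3ccc(C#N)cc3)[nH]c(=O)c2I)c1`: 24000 nM
- compound 3 `COc1cc(Oc2c(C)cc(C#N)cc2C)cc(Nc2ccc(C#N)cc2)n1`: > 147000 nM

For compound 3, the entry > 147000 nM is a limit of the assay and not a number.

Of the two true numbers, compound 2 holds the lower, at 24000 nM. Compound 1 gives 63000 nM, and the gap from compound 2 lies beyond the scatter.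

The next compound is compound 4 `Cc1cc(C)c(Oc2cc(Nc3ccc(C#N)cc3)[nH]c(=O)c2I)c(C)c1`, which differs from compound 2 in one place: 2,4,6-trimethylphenyl in place of 3,5-dimethylphenyl on an oxygen on an aromatic ring. In words, 2,4,6-trimethylphenyl stands in place of 3,5-dimethylphenyl on an oxygen on an aromatic ring.

For the measured compounds named here, no measured pair differs in one place only, so the size of this step has no direct precedent. The expectation rests on the two numbers from compound 2 at 24000 nM and compound 1 at 63000 nM. No step beyond the scatter is expected in this assay, and the expected change is a 1.3-fold higher number from compound 2 to compound 4 (0.10 log units; within the scatter).

For compound 4 the estimated half-maximal cytotoxic concentration is 30000 nM, with an expected range of 9000 nM to 90000 nM.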

Compound 4, half-maximal cytotoxic concentration: 34000 nM
Beside the measured number, compound 4's estimate is 1.1-fold (0.05 log units) below it; the range from low to high includes it.
By their numbers in this assay, from the lowest: compounds 2, 4 and 1 (each within the scatter of the next, the first and the last beyond it). At a limit, above all of these: compound 3.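

In this assay, 2,4,6-trimethylphenyl in place of 3,5-dimethylphenyl on the oxygen gives a 1.4-fold higher number from compound 2 to compound 4 (0.15 log units; within the scatter), on an otherwise unchanged core. For the compounds shown here, this is the first one-place comparison, and for this pair the change of methyl pattern on this ring brings no step beyond the scatter. The one limit in the set belongs to compound 3, is not a number and plays no part in this step: the limit of > 147000 nM in this assay, at which 1 of the 4 values shown sits.

As far as these compounds go, whether an amine or a carboxylic acid on this ring would bring a step beyond the scatter stays open. From the compounds shown here alone, compound 1 and compound 3 each differ from compound 2 and compound 4 in more than one place, so steps to them cannot be read, and whether this change reads the same on another core also stays open.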